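The source may hold more compounds than are shown below. What is called first, only, known or untested is meant among the compounds shown, and "the series" means these compounds.

The three measured compounds:
compound 1, `CN(c1ccc(Oc2ncnc3ccsc23)cc1)c1nccc(N2CCc3ccccc3C2)n1`, 58.3%
compound 2, `CN(c1ccc(Oc2ncnc3ccsc23)cc1)c1nccc(N2CCCCC2)n1`, 66.2%
compound 3, `CN(c1ccc(Oc2ncnc3sccc23)cc1)c1nccc(N2CCCCC2)n1`, 52.2%

In a functional assay on HCT-116 cells (Homo sapiens) for inhibition, read by MTT assay, with a stated time of 72 h, tested at 20 uM (a higher number here means more inhibition at the concentration tested (going by the name of the read-out), a lower number less inhibition), compound 2 gives the highest of the three numbers. The gap to compound 1 is within the scatter: a number 7.9 percentage points higher from compound 1 to compound 2 (within the scatter). The gap to compound 3 is beyond it: a number 14 percentage points lower from compound 2 to compound 3 (beyond the scatter). Compound 4, `c1cc(N2CCCCC2)nc(Nc2ccc(Oc3ncnc4ccsc34)cc2)n1`, differs from compound 2 in one place: hydrogen in place of methyl on a nitrogen on an aromatic ring. Neither measured step touches this nitrogen; one changes a ring on an aromatic carbon, the other swaps the group on the aromatic oxygen. So no measured step bears directly on this change, and the expectation rests on compound 2 alone. The expected step is small: a number 6.2 percentage points lower from compound 2 to compound 4 (within the scatter). For compound 4 the estimate is 60%, between 40% and 80%.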

Compound 4, a percentage reported as inhibition, at one concentration (the size of the read-out at that concentration, not a potency): 61.5%
Compound 4: middle estimate off by 1.5 percentage points, on the low side; the range from low to high includes it.
By their numbers in this assay, from the lowest: compounds 3, 1, 4 and 2 (each within the scatter of the next, the first and the last beyond it).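

In this assay, the change at this nitrogen gives a number 4.7 percentage points lower from compound 2 to compound 4 (within the scatter), so on this compound the nitrogen can carry hydrogen or methyl without a difference beyond the scatter. This is the only pair shown that tests this position, and it covers just the smallest swap there. No measurement shown gives a reason for this result.

From the compounds shown here alone, whether an ethyl, benzyl or acetyl group on this nitrogen would give a similar number remains open. So does whether the same swap would hold with 1,2,3,4-tetrahydroisoquinolin-2-yl on the ring, as in compound 1, or on the core of compound 3.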